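The source may report more compounds than this note shows. Statements on the series, on what has been measured and on what is new or still open speak of the compounds shown alone.

Compound 1 `O=C(CN1CCN(c2nnc(Cc3ccncc3)c3ccccc23)CC1)Nc1cccc(Br)c1`: 1.7 nM
Compound 2 `Cc1cccc(Cl)c1NC(=O)CN1CCN(c2nnc(Cc3ccccc3)c3ccccc23)CC1`: 3920 nM
Compound 3 `O=C(CN1CCN(c2nnc(Cc3ccncc3)c3ccccc23)CC1)Nc1ccc(F)c(Cl)c1`: 4 nM

All three values come from a functional assay on MDA-MB-231 cells (Homo sapiens) for cytotoxicity, read by MTT assay, with a stated time of 72 h; a higher number here means a weaker inhibitor, a lower number a stronger inhibitor. Compound 3 holds the middle of the three numbers, close to compound 1 and far under compound 2.

Compound 4 `Cc1cccc(Cl)c1NC(=O)CN1CCN(c2nnc(Cc3ccncc3)c3ccccc23)CC1` carries 2-chloro-6-methylphenyl in place of 3-chloro-4-fluorophenyl on an amide-type nitrogen.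

Going by the values given here, only one measured step changes this same place, a 2.4-fold higher number from compound 1 to compound 3 (0.37 log units; beyond the scatter), and it is modest. Compound 2 has the entering 2-chloro-6-methylphenyl group and gives 3920 nM, but it also differs from compound 4 elsewhere in the core. Among the compounds with values here, no measured step separates these two differences, so compound 2 is only a warning that this group may go with a much higher number in this assay. Within the data shown here, a move to a higher number is therefore expected, larger than the step from the one measured swap but well short of the full gap to compound 2.

The expected change is a 10-fold higher number from compound 3 to compound 4 (1.00 log units; beyond the scatter). For compound 4 the estimated value is 40 nM, with an expected range of 4 nM to 800 nM.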

Compound 4, half-maximal inhibitory concentration: 2670 nM
Compound 4: middle estimate off by 67-fold (1.82 log units), on the low side; measured number outside the range, above it.
By their numbers in this assay, from the lowest: compound 1; then compound 3; then compounds 4 and 2 (each within the scatter of the next).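

On the amide-type nitrogen, in this assay, 2-chloro-6-methylphenyl brings a far larger shift than the swap seen earlier, a 2.4-fold higher number from compound 1 to compound 3 (0.37 log units; beyond the scatter): the new group gives a 670-fold higher number from compound 3 to compound 4 (2.82 log units; beyond the scatter) and a 1600-fold higher number from compound 1 to compound 4 (3.20 log units; beyond the scatter). With 2-chloro-6-methylphenyl held on that nitrogen, pyridin-4-yl in place of phenyl gives a 1.5-fold lower number from compound 2 to compound 4 (0.17 log units; within the scatter), so among these compounds the large gap follows the group on the amide-type nitrogen and not the pyridin-4-yl or phenyl group. Nothing at hand explains why this group has so large an effect.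

Still open, going by these compounds, is whether the chlorine or the methyl accounts for the shift, which 2-chlorophenyl, 2-methylphenyl or plain phenyl on the same nitrogen would address. Also open, on these data alone, is whether phenyl in place of pyridin-4-yl stays as silent when 3-bromophenyl sits on the amide-type nitrogen.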